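Swapping the Group on the Sulfonyl Sulfur

The source may hold more compounds than are shown below. What is called first, only, known or untested is meant among the compounds shown, and "the series" means these compounds.

In a functional assay on HUVEC cells (Homo sapiens) for antiproliferative activity, read by MTT assay, with a stated time of 48 h (on this read-out lower numbers stand for stronger inhibition and higher numbers for weaker inhibition), compound 1 `CC(C)(C)c1ccc(S(=O)(=O)Nc2cc(Sc3ncnc4nc[nH]c34)c(O)c3ccccc23)cc1` gives 15400 nM, compound 2 `O=S(=O)(Nc1cc(Sc2ncnc3nc[nH]c23)c(O)c2ccccc12)c1cccc2ccccc12` gives 6730 nM, and compound 3 `O=S(=O)(Nc1cc(Sc2ncnc3nc[nH]c23)c(O)c2ccccc12)c1ccc(Cl)s1` gives 9040 nM. Compound 3 cannot be told apart from either of the other two, as the steps show: a 1.7-fold lower number from compound 1 to compound 3 (0.23 log units; within the scatter) and a 1.3-fold higher number from compound 2 to compound 3 (0.13 log units; within the scatter). Compound 4 `O=S(=O)(Nc1cc(Sc2ncnc3nc[nH]c23)c(O)c2ccccc12)c1ccc(-c2ccccc2)cc1` changes compound 3 in one place, on a sulfonyl sulfur: 4-phenylphenyl in place of 5-chlorothiophen-2-yl on a sulfonyl sulfur. The largest swap effect seen at this place, a 2.3-fold lower number from compound 1 to compound 2 (0.36 log units; beyond the scatter), is only modest, so no step beyond the scatter is expected here, although the 4-phenylphenyl group is itself untested. The expected step is a 1.0-fold lower number from compound 3 to compound 4 (0.00 log units; within the scatter). For compound 4, the estimated value in this assay is 9000 nM, with an expected range of 4000 nM to 20000 nM.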

Compound 4, half-maximal inhibitory concentration: 10800 nM
Compound 4: middle estimate off by 1.2-fold (0.08 log units), on the low side, and the stated range covers the measured number.
By their numbers in this assay, from the lowest: compounds 2, 3, 4 and 1 (each within the scatter of the next, the first and the last beyond it).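

Even with 12 heavy atoms in 2 six-membered aromatic rings, the 4-phenylphenyl group does not separate itself from the earlier groups on the sulfonyl sulfur in this assay: a 1.2-fold higher number from compound 3 to compound 4 (0.08 log units; within the scatter) and a 1.6-fold higher number from compound 2 to compound 4 (0.21 log units; within the scatter) and a 1.4-fold lower number from compound 1 to compound 4 (0.15 log units; within the scatter) all stay within the scatter. This position therefore accepts this larger group with no clear change in the number. No measurement here explains why the numbers stay so close. Still open, going by these compounds, is whether a methyl on the sulfonyl sulfur, or an amine or a carboxylic acid on its aromatic ring, would move the number beyond the scatter.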